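The source may report more compounds than this note shows. Statements on the series, on what has been measured and on what is new or still open speak of the compounds shown alone.

Working notes on the series. Compound 1 `O=C(CSc1nnc(-c2ccncc2)o1)N/N=C/c1ccccc1` gives 14600 nM in a functional assay on MCF7 cells (Homo sapiens) for cytotoxicity, read by MTT assay, with a stated time of 48 h (a higher number here means a weaker inhibitor, a lower number a stronger inhibitor), the highest of the two numbers in hand. For the measured compounds named here, compound 2 `O=C(CSc1nnc(-c2ccncc2)o1)N/N=C/c1ccc(O)cc1`, which carries hydroxy in place of hydrogen on an aromatic carbon, gives 11700 nM in this assay; the step of a 1.2-fold lower number from compound 1 to compound 2 (0.10 log units; within the scatter) is the only measured step and does not rise beyond the scatter.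

Compound 3 `O=C(CSc1nnc(-c2ccncc2)o1)N/N=C/c1ccc(O)c(O)c1` is not yet measured. Against compound 1 the change is 3,4-dihydroxyphenyl in place of phenyl on a carbon with a double bond to nitrogen. The one step that bears on it, a 1.2-fold lower number from compound 1 to compound 2 (0.10 log units; within the scatter), covers only a single hydroxy and was small, so on the numbers shown no step beyond the scatter is expected for compound 3, with the direction, if any, toward a lower number, the expected step being a 1.6-fold lower number from compound 1 to compound 3 (0.21 log units; within the scatter). Compound 3 is therefore estimated at 9000 nM in this assay, with a range from 3500 nM to 25000 nM.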

Compound 3, half-maximal inhibitory concentration: 910 nM
Compound 3: the middle estimate sits 9.9-fold (1.00 log units) above what was measured; the measured number lies below the stated range.
By their numbers in this assay, from the lowest: compound 3; then compounds 2 and 1 (each within the scatter of the next).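

In this assay the group on the carbon with a double bond to nitrogen can move the number well beyond the scatter: 3,4-dihydroxyphenyl in place of phenyl gives a 16-fold lower number from compound 1 to compound 3 (1.21 log units; beyond the scatter), and one further hydroxy on compound 2 gives a 13-fold lower number from compound 2 to compound 3 (1.11 log units; beyond the scatter). The single hydroxy step, a 1.2-fold lower number from compound 1 to compound 2 (0.10 log units; within the scatter), did not show this, so among these three compounds the large step appears only with both hydroxy groups present. Nothing measured on these compounds accounts for that step.

The compounds shown leave open whether both free hydroxy groups are required, which a 3,4-dimethoxyphenyl or a 3,4-diaminophenyl group at the same place would test. They also leave open whether the step from a further hydroxy holds when the rest of the shared core is changed.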